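Methylation of a Phenolic Oxygen Across Three Measured Limits

This account rests on a few compounds, and the source may have more. Where it says the series, first, only, none or still open, it means among the compounds named here.

Compound 1 `COC(=O)c1c(-c2cc(OC)cc(OC)c2)oc2ccccc2c1=O`. In a functional assay on Malme-3M cells (Homo sapiens) for cytotoxicity, read by MTT assay, with a stated time of 6 days (on this read-out higher numbers stand for an effect only at larger amounts of compound and lower numbers for an effect already at smaller amounts), compound 1 gives > 25 ug/mL, a limit of the assay.
Compound 2 `COc1cc(OC)cc(-c2oc3ccccc3c(=O)c2C(=O)O)c1`. In this assay compound 2 gives > 25 ug/mL, a limit of the assay.
Compound 3 `COc1cc(-c2cc(=O)c3cc(O)ccc3o2)cc(OC)c1OC`. In this assay compound 3 gives > 25 ug/mL, a limit of the assay.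

The cores of compound 2 and compound 3 differ, but that difference is not broken down here. From compound 2 to compound 1 the change is methyl in place of hydrogen on an oxygen next to a carbonyl group. The step that the two limits leave unreadable from compound 2 to compound 1 cannot be read as a size, since the limit of > 25 ug/mL in this assay, at which 3 of the 3 values shown sit, sits at both of its ends.

Compound 4 `COc1ccc2oc(-c3cc(OC)c(OC)c(OC)c3)cc(=O)c2c1` has not yet been measured. It differs from compound 3 by methyl in place of hydrogen on an oxygen on an aromatic ring. Among the measured compounds shown here, this is the same kind of change as the one from compound 2 to compound 1, not the same: there the oxygen stood next to a carbonyl group, with a carbonyl carbon as its other neighbour, whereas here the oxygen sits on an aromatic ring, with an aromatic carbon as its other neighbour.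

For the measured compounds named here, with every measured value sitting at the limit of this assay, the one measured instance of this kind of change gives no size to lean on. The expectation for compound 4 therefore rests on (the limit of > 25 ug/mL in this assay, at which 3 of the 3 values shown sit), where compound 1, compound 2 and compound 3 all sit, and the step from compound 3 to compound 4 is expected to be a step that the limit leaves unreadable from compound 3 to compound 4. Compound 4 is estimated at 35 ug/mL, between 15 ug/mL and 100 ug/mL, and is most likely to be reported only as a limit.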

Compound 4, concentration for half-maximal effect: > 25 ug/mL
Compound 4 ended at the assay's limit (the forecaster's own chance of this, stated with the estimate: 75%); the middle value is on the limit's open side.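

In this assay compound 3 and compound 4 both sit at a limit of the assay, so no size can be read for the change from hydroxy to methoxy between them: the limit of > 25 ug/mL in this assay, at which 4 of the 4 values shown sit.

The compounds shown leave open how large either change of hydrogen to methyl is in this assay, and whether the place of the oxygen makes any difference to its size.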